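The source may report more compounds than this note shows. Statements on the series, on what has been measured and on what is new or still open speak of the compounds shown alone.

Of the compounds shown here, three sharing one core have been tested in an ADME assay on MT4 cells (Homo sapiens) for cytotoxicity, read by MTT assay; a higher number here means that more compound is tolerated, a lower number that less compound is tolerated. Compound 1 `Cc1cc(C)cc(S(=O)(=O)c2c(C(=O)NCc3cccc(F)c3F)[nH]c3ccc(Cl)cc23)c1` reports only a limit there, > 51100 nM, and no number. Compound 2 `Cc1cc(C)cc(S(=O)(=O)c2c(C(=O)NCc3ccc4nc(N)[nH]c4c3)[nH]c3ccc(Cl)cc23)c1` gives 5890 nM. Compound 3 `Cc1cc(C)cc(S(=O)(=O)c2c(C(=O)NCC(=O)NC(C)c3ccncc3)[nH]c3ccc(Cl)cc23)c1` gives 47000 nM, the highest of the two numbers that are known; its nearest neighbour is compound 2, and the step between them, an 8.0-fold higher number from compound 2 to compound 3 (0.90 log units; beyond the scatter), lies beyond the scatter.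

Compound 4 `Cc1cc(C)cc(S(=O)(=O)c2c(C(=O)NCc3n[nH]c4ccccc34)[nH]c3ccc(Cl)cc23)c1` has not yet been measured. It differs from compound 3 in one place: 1H-indazol-3-yl in place of (1-(pyridin-4-yl)ethyl)carbamoyl on a saturated chain carbon bound to an amide-type nitrogen.

Going by the values given here, two measured steps bear on this change, both at the same saturated chain carbon. Replacing the 2,3-difluorophenyl of compound 1 by a two-ring aromatic group bearing a ring nitrogen with its hydrogen gave an at least 8.6-fold lower number from compound 1 to compound 2 (0.93 log units; beyond the scatter), and the reverse exchange toward the carbamoyl chain gave an 8.0-fold higher number from compound 2 to compound 3 (0.90 log units; beyond the scatter). The entering 1H-indazol-3-yl is again a fused two-ring aromatic group with one hydrogen-bond donor, closer in kind to the group of compound 2 than to the chain of compound 3. A lower number is therefore expected for compound 4, of a size between the scatter and the steps already seen, that is a 3.4-fold lower number from compound 3 to compound 4 (0.53 log units; beyond the scatter). Compound 4 is estimated at 14000 nM, with a likely range from 4500 nM to 45000 nM.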

Compound 4, half-maximal cytotoxic concentration: > 50700 nM
Compound 4 ended at the assay's limit; the forecaster's own chance of this, stated with the estimate: 12%; at least 3.6-fold (0.55 log units) between middle value and limit.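

In this assay compound 4 reports a limit and no number: the limit of > 50700 nM in this assay, at which 1 of the 4 values shown sits.

So a fused two-ring aromatic group at this place, on a saturated chain carbon bound to an amide-type nitrogen, does not by itself go with a low number: 1H-indazol-3-yl in place of 2-amino-1H-benzimidazol-6-yl gives an at least 8.6-fold higher number from compound 2 to compound 4 (0.93 log units; beyond the scatter). Among the two-ring groups shown, the lower number belongs to the 2-amino-1H-benzimidazol-6-yl of compound 2 and not to the 1H-indazol-3-yl of compound 4. Exchanging the (1-(pyridin-4-yl)ethyl)carbamoyl chain for 1H-indazol-3-yl gives an at least 1.0-fold higher number from compound 3 to compound 4 (0.03 log units; that floor lies within the scatter), a floor within the scatter, so these two groups cannot be told apart or put in order here.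

From the compounds shown here alone, the step between compound 1 and compound 4 cannot be read, and how far compound 4 lies past its limit remains unknown. Going by these compounds, it also remains open whether the amine of the 2-amino-1H-benzimidazol-6-yl goes with the lower number of compound 2; the same group without that amine, or a 1H-indazol-3-yl carrying an amine, would address this.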